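A few compounds are considered here, and "the series" means these few. Any claim that something is new, unique, unknown or untested is made for them only; others in the source may bear on it.

Measured compounds:
Compound 1 `O=C(O)c1cc(-c2cccc(COc3ccc4c(c3)CN(C3CCCC3)C4=O)c2)ccc1O`: in an ADME assay on microsomes from liver (Rattus norvegicus) for metabolic stability, read by LC-MS, with a stated time of 1 h, at 37 degrees C, tested at 4 uM (a lower number here means that less of the compound is left, a higher number that more of the compound is left), compound 1 gives 9%.
Compound 2 `O=C1c2ccc(OCc3cccc(-c4ccc(C(F)(F)F)cc4F)c3)cc2CN1C1CCCC1`: in this assay compound 2 gives "not determined" (no result reported), so no number is available for it.
Compound 3 `COc1ccc(-c2cccc(COc3ccc4c(c3)CN(C3CCCC3)C4=O)c2)cc1C(=O)O`: in this assay compound 3 gives 84%.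

For the measured compounds named here, compound 3 stands highest of the two numbers available, with compound 1 as its only neighbour far below it. Going by the values given here, the single measured step, a number 75 percentage points higher from compound 1 to compound 3 (beyond the scatter), shows that a small change on the outer ring can move this read-out a great deal.

Compound 4 `Cc1ccc(C(=O)O)cc1-c1cccc(COc2ccc3c(c2)CN(C2CCCC2)C3=O)c1` differs from compound 3 in one place: 5-carboxy-2-methylphenyl in place of 3-carboxy-4-methoxyphenyl on an aromatic carbon. Among the compounds with values here, this change is of a different kind from the one between compound 1 and compound 3, so that step bears on it only loosely: it shows the outer ring matters, but not how a methyl in place of a methoxy, with the carboxylic acid shifted, will behave. The carboxylic acid stays in place, as it does in compound 3.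

On that basis, compound 4 is expected to remain fairly stable, with a modest step downward from compound 3, a number 14 percentage points lower from compound 3 to compound 4 (beyond the scatter), that may or may not exceed the scatter. The estimate for compound 4 is 70%, with a range from 45% to 90%.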

Compound 4, percent of the compound remaining: 2%
Compound 4: the middle estimate sits 68 percentage points above what was measured; measured number below the stated range.
By their numbers in this assay, from the lowest: compounds 4 and 1 (each within the scatter of the next); then compound 3.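

Replacing 3-carboxy-4-methoxyphenyl with 5-carboxy-2-methylphenyl on this aromatic carbon gives a number 82 percentage points lower from compound 3 to compound 4 (beyond the scatter) in this assay, so a carboxylic acid on the outer ring, together with one small extra group, is not enough to carry over the high reading of compound 3. Measured against the 3-carboxy-4-hydroxyphenyl ring, the same position gives a number 7 percentage points lower from compound 1 to compound 4 (within the scatter), which means two quite different outer rings read alike here and only the 3-carboxy-4-methoxyphenyl ring stands apart among the three numbers available. The data at hand offer no measurement that would explain the size of this drop.

The change alters two things at once, with a methyl taking over from the methoxy and the carboxylic acid sitting elsewhere on the ring, so these compounds cannot separate the share of each in the step. Also open, as far as these compounds go, is how the outer ring would read with an ethoxy or an amine in place of the methoxy, or with a tetrazole in place of the carboxylic acid.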